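The source may hold more compounds than are shown below. What is called first, only, known or untested is meant among the compounds shown, and "the series" means these compounds.

Measured compounds: compound 1 `Fc1ccc(COc2nc3ccccc3s2)cc1` with 51.9%; compound 2 `COc1ccc(COc2nc3ccccc3s2)cc1` with "not active" (no number reported).

The account follows the step from compound 2 to compound 3. Compound 2 `COc1ccc(COc2nc3ccccc3s2)cc1` stands without a single number: in a functional assay on the whole organism with Mus musculus as the target, in the writhing test, at a dose of 100 mg/kg by the intraperitoneal route (on this read-out lower numbers stand for less inhibition and higher numbers for more inhibition at the one dose given (going by the name of the read-out)), compound 2 is reported as "not active" (no number reported), and no figure for the read-out was given. Compound 1 `Fc1ccc(COc2nc3ccccc3s2)cc1` shows that the shared core can reach a clear read-out, since in this assay compound 1 gives 51.9%.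

Compound 3 `Brc1ccc(COc2nc3ccccc3s2)cc1` has not yet been measured. It differs from compound 2 in one place: bromo in place of methoxy on an aromatic carbon. Among the compounds with values here, no step between two measured compounds is available to set the size of this change, so the expectation rests on the two anchors alone. The step from compound 2 to compound 3 in this assay is expected to run upward, beyond the scatter, because compound 1 reaches 51.9% while compound 2 is reported as "not active" (no number reported). Compound 3 is estimated at 40%, with a range from 10% to 65%.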

Compound 3, a percentage reported as inhibition, in the whole organism at one dose (the size of the read-out at that dose, not a potency): 51.9%
For compound 3 the middle estimate is 11.9 percentage points below the measured one, within the range that was stated.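

In this assay, the result shows that the read-out at this place, on an aromatic carbon para to a large group, does not depend on fluoro alone: bromo in place of fluoro on an aromatic carbon gives no change at the digits printed from compound 1 to compound 3 (within the scatter), so a single bromine serves here as well as fluoro does in the shared core. Methoxy remains the one group of the three without a figure, since compound 2 is reported as "not active" (no number reported), and the step from it to either of the other two cannot be read as a size, although bromo now joins fluoro as a replacement for methoxy that comes with a clear number. Nothing shown gives any measured property of these groups that would account for the difference between methoxy and the other two, so the result stands as an observation only.

As far as these compounds go, whether the read-out at this place would hold with chloro, or would be lost with an amine or a carboxylic acid, stays open. So does the question of whether methoxy fails through its oxygen, which a plain methyl or a longer chain such as ethyl at the same place could begin to settle.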